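Compound 1 and the loss of a methoxy

This account rests on a few compounds, and the source may have more. Where it says the series, first, only, none or still open, it means among the compounds named here.

Among the measured compounds shown here, in a functional assay on MCF7 cells (Homo sapiens) for antiproliferative activity, read by MTT assay, with a stated time of 48 h (on this read-out higher numbers stand for weaker inhibition and lower numbers for stronger inhibition), compound 1 (`COc1ccc2c(/C=C/C(=O)c3cc(OC)c(OC)c(SC)c3)c[nH]c2c1`) gives 101 nM and holds the lowest of the three numbers so far. Compound 2 (`COc1ccc2c(/C=C/C(=O)c3cc(N)c(OC)c(OC)c3)c[nH]c2c1`) gives 249 nM in this assay and compound 3 (`COc1ccc2c(/C=C/C(=O)c3cc(OC)c(OC)c([N+](=O)[O-])c3)c[nH]c2c1`) gives 662 nM there. Compound 4 (`COc1cc(C(=O)/C=C/c2c[nH]c3ccccc23)cc(SC)c1OC`) is still unmeasured. Its difference from compound 1 is hydrogen in place of methoxy on an aromatic carbon and amounts to hydrogen in place of methoxy on an aromatic carbon.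

For the measured compounds named here, none of the measured steps touches this methoxy, so the data offer no direct test. They serve only as a yardstick of size: a 2.5-fold higher number from compound 1 to compound 2 (0.39 log units; beyond the scatter) is one, a 2.7-fold higher number from compound 2 to compound 3 (0.42 log units; beyond the scatter) is another, and a 6.6-fold higher number from compound 1 to compound 3 (0.82 log units; beyond the scatter) is the largest. All three are modest yet beyond the scatter. A modest move towards weaker inhibition in this assay is therefore expected, with low confidence in its direction. The expected step is a 2.5-fold higher number from compound 1 to compound 4 (0.39 log units; beyond the scatter) as an estimate only. For compound 4 the estimated value is 250 nM with an expected range from 80 nM to 800 nM.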

Compound 4, half-maximal inhibitory concentration: 186 nM
For compound 4 the middle estimate is 1.3-fold (0.13 log units) above the measured one; low and high end bracket the measured number.
By their numbers in this assay, from the lowest: compounds 1, 4 and 2 (each within the scatter of the next, the first and the last beyond it); then compound 3.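

In this assay, hydrogen in place of methoxy on an aromatic carbon of the fused system gives a 1.8-fold higher number from compound 1 to compound 4 (0.27 log units; within the scatter), so this is a step within the scatter, unlike all three steps among compounds 1, 2 and 3, which are printed as beyond it. This methoxy is therefore not shown to be needed for a value in the range of compound 1, at least while methylsulfanyl is kept on the other ring. No measurement available here bears on why this position accepts the change.

As far as these compounds go, whether a hydroxyl group, a fluorine atom or an ethoxy group at this position would also stay within the scatter of compound 1 remains open. Also open, from the compounds shown here alone, is whether hydrogen in place of this methoxy would be tolerated alongside the amino group of compound 2 or the nitro group of compound 3.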